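Aryl swap on the four-membered ring: compound 2 to 3

The source may hold more compounds than are shown below. What is called first, only, known or untested is meant among the compounds shown, and "the series" means these compounds.

Measured in a functional assay on MCF7 cells (Homo sapiens) for antiproliferative activity, read by MTT assay, with stated times of 24 h and 72 h; on this read-out lower numbers stand for stronger inhibition and higher numbers for weaker inhibition:
- compound 1 `COc1ccc([C@@H]2[C@H](Oc3ccccc3)C(=O)N2c2cc(OC)c(OC)c(OC)c2)cc1`: 35000 nM
- compound 2 `COc1cc(N2C(=O)[C@@H](Oc3ccccc3)[C@H]2c2ccc(S(C)(=O)=O)cc2)cc(OC)c1OC`: 62000 nM

Only these two compounds have been measured so far. Within the data shown here, compound 2, at 62000 nM, has compound 1 as its only neighbour, and the two values lie within the scatter of each other.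

The next compound is compound 3 `COc1cc(N2C(=O)[C@@H](Oc3ccccc3)[C@H]2c2ccc(O)c(O)c2)cc(OC)c1OC`, still unmeasured. The change is 3,4-dihydroxyphenyl in place of 4-(methylsulfonyl)phenyl on a saturated ring carbon.

Among the measured compounds shown here, one measured step bears on this place. Methylsulfonyl in place of methoxy on an aromatic carbon of that same aryl group gave a 1.8-fold higher number from compound 1 to compound 2 (0.25 log units; within the scatter). For the measured compounds named here, that step is small, but it is a single step, and no measured compound carries 3,4-dihydroxyphenyl, so the evidence for this change is thin. As far as these compounds go, no shift beyond the scatter is therefore expected, and the direction stays open, with a wide range.

In this assay the estimate means a 1.6-fold lower number from compound 2 to compound 3 (0.19 log units; within the scatter), an expected step that stays within the scatter. For compound 3 the estimated value is 40000 nM, with an expected range of 10000 nM to 100000 nM.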

Compound 3, half-maximal inhibitory concentration: 4500 nM
Beside the measured number, compound 3's estimate is 8.9-fold (0.95 log units) above it, and the stated range ends above it.
By their numbers in this assay, from the lowest: compound 3; then compounds 1 and 2 (each within the scatter of the next).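

In this assay, this position on the saturated ring carbon of the four-membered ring proves responsive to the aryl group: 3,4-dihydroxyphenyl in place of 4-(methylsulfonyl)phenyl gives a step beyond the scatter (a 14-fold lower number from compound 2 to compound 3 (1.14 log units; beyond the scatter)), whereas the earlier exchange of methoxy for methylsulfonyl stayed within it (a 1.8-fold higher number from compound 1 to compound 2 (0.25 log units; within the scatter)). The gain does not hang on one reference compound, since 3,4-dihydroxyphenyl in place of 4-methoxyphenyl also lies beyond the scatter (a 7.8-fold lower number from compound 1 to compound 3 (0.89 log units; beyond the scatter)), although the two starting compounds are within the scatter of each other. Nothing measured here accounts for the change.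

The compounds shown leave open whether both hydroxyl groups are needed, or whether a single hydroxyl, or an amine or a fluorine in place of one hydroxyl, would keep the lower number. They also leave open whether 3,4-dihydroxyphenyl would give a similar step with another group in place of the phenoxy group on the neighbouring ring atom, since all three compounds carry phenoxy there.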